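A few compounds are considered here, and "the series" means these few. Any claim that something is new, unique, unknown or untested is made for them only; others in the source may bear on it.

Measured compounds:
compound 1, `COc1ccc(Cl)cc1N(CC(=O)N1CCCCC1)S(=O)(=O)c1ccccc1`, in a functional assay on SH-SY5Y cells (Homo sapiens), read by MTT assay, with a stated time of 24 h (a higher number here means that more compound is needed for the effect, a lower number that less compound is needed), compound 1 gives 14500 nM.
compound 2, `COc1ccc(Cl)cc1N(CC(=O)Nc1ccc(C(F)(F)F)cc1)S(=O)(=O)c1ccccc1`, in this assay compound 2 gives 3750 nM.

Among the compounds with values here, compound 2 holds the lowest of the two numbers; the only other measured compound is compound 1, and the single step measured runs a 3.9-fold lower number from compound 1 to compound 2 (0.59 log units; beyond the scatter). Compound 3, `COc1ccc(Cl)cc1N(CC(=O)Nc1ccc([N+](=O)[O-])cc1)S(=O)(=O)c1ccccc1`, differs from compound 2 by nitro in place of trifluoromethyl on an aromatic carbon. Within the data shown here, no measured step concerns this part of the molecule: the one step in hand changes the group on the carbonyl carbon and says nothing about what sits on the aromatic ring of the (4-(trifluoromethyl)phenyl)amino group. In the absence of a bearing step, the account expects the number for compound 3 to stay close to that of compound 2 in this assay, with any step in either direction no larger than the usual scatter. Compound 3 is therefore estimated at 4000 nM, within 1500 nM to 11000 nM, an expected step of a 1.1-fold higher number from compound 2 to compound 3 (0.03 log units; within the scatter).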

Compound 3, half-maximal effective concentration: 8210 nM
Beside the measured number, compound 3's estimate is 2.1-fold (0.31 log units) below it, within the range that was stated.
By their numbers in this assay, from the lowest: compound 2; then compounds 3 and 1 (each within the scatter of the next).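

In this assay the group on the aromatic carbon para to a large group proves to count: nitro in place of trifluoromethyl gives a 2.2-fold higher number from compound 2 to compound 3 (0.34 log units; beyond the scatter) in a modest step, the first measured at this place. Changing piperidin-1-yl to (4-nitrophenyl)amino gives a 1.8-fold lower number from compound 1 to compound 3 (0.25 log units; within the scatter) and so does not separate compound 3 from compound 1, which shows that the earlier advantage of compound 2 over compound 1 does not carry over to every 4-substituted phenylamino group tested. Nothing measured here accounts for the difference between trifluoromethyl and nitro.

Going by these compounds, what a nitrile, an amine or a carboxylic acid at this same place would give remains open. So does the effect of a phenyl ring with no group at this place, and of any change to the methoxy group or the chlorine on the shared core.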